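Phenyl Replacing Methylsulfonyl on the Core of Compound 3

The source may hold more compounds than are shown below. What is called first, only, known or untested is meant among the compounds shown, and "the series" means these compounds.

Compound 1 `O=C(CCCCCCc1ccccc1)c1nnc(-c2cccs2)s1`: > 10000 nM
Compound 2 `O=C(CCCCCCc1ccccc1)c1nnc(-c2ccccc2)[nH]1`: > 10000 nM
Compound 3 `CS(=O)(=O)c1coc(C(=O)CCCCCCc2ccccc2)n1`: 389 nM

Of the compounds shown here, three have been measured in an assay on HEK-293T cells for inhibition of diacylglycerol lipase-alpha (Homo sapiens), read by colorimetric assay; a higher number here means a weaker inhibitor, a lower number a stronger inhibitor. Compound 1 reaches only a limit there, > 10000 nM. Compound 2 also stops at a limit, > 10000 nM. Among the measured compounds shown here, compound 3 is the single compound that returns a number, 389 nM, so it stands alone among the values shown, the other two sitting at the limit of > 10000 nM in this assay, at which 2 of the 3 values shown sit. Compound 4 `O=C(CCCCCCc1ccccc1)c1nc(-c2ccccc2)co1` has not yet been measured. It differs from compound 3 in one place: phenyl in place of methylsulfonyl on an aromatic carbon. For the measured compounds named here, no step between measured compounds exists, but the two compounds at the limit are those without a methylsulfonyl group. The step from compound 3 to compound 4 is therefore expected to weaken inhibition, a 7.7-fold higher number from compound 3 to compound 4 (0.89 log units; beyond the scatter). Compound 4 is estimated at 3000 nM, between 600 nM and 20000 nM.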

Compound 4, half-maximal inhibitory concentration: 8710 nM
For compound 4 the middle estimate is 2.9-fold (0.46 log units) below the measured one, and the stated range covers the measured number.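

Among the compounds shown here, this gives the first measured step at this position. In this assay, phenyl in place of methylsulfonyl on the aromatic carbon next to the ring nitrogen gives a 22-fold higher number from compound 3 to compound 4 (1.35 log units; beyond the scatter), so inhibition at this position is sensitive to this exchange of groups. Compound 4 still returns a number, not a limit of the kind reached elsewhere in the series: the limit of > 10000 nM in this assay, at which 2 of the 4 values shown sit.

A single exchange cannot show whether the loss comes from removing methylsulfonyl or from adding phenyl. From the compounds shown here alone, how a methyl group, a sulfonamide or a carboxylic acid on this carbon would fare remains open.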